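The source may hold more compounds than are shown below. What is called first, only, known or untested is meant among the compounds shown, and "the series" means these compounds.

Working notes on a small series tested in an assay on isolated protein for inhibition of DNA topoisomerase 1 (Homo sapiens), with a stated time of 30 min, tested at 100 uM; on this read-out lower numbers stand for a weaker effect and higher numbers for a stronger effect at the one concentration tested. Compound 1 `Oc1ccc(-c2cc(-c3cccnc3)nc(-c3ccccc3Cl)c2)cc1` gives 0.9% in this assay. Within the data shown here, compound 2 `Oc1cccc(-c2cc(-c3ccc(Cl)cc3)nc(-c3cccs3)c2)c1` gives 15.1% in this assay, the higher of the two numbers measured so far; its nearest neighbour is compound 1, whose number lies lower by a gap beyond the usual scatter. Among the measured compounds shown here, with only two compounds measured, no single-change step between measured compounds is available, so the expectation below rests on the value of compound 2 and on the structural change alone. Compound 3 `Oc1cccc(-c2cc(-c3ccc(Cl)cc3)nc(-c3ccco3)c2)c1` has not yet been measured. It differs from compound 2 in one place: furan-2-yl in place of thiophen-2-yl on an aromatic carbon. The change is expected to be small, either no shift beyond the scatter or a slight loss, and the step is estimated as a number 3.1 percentage points lower from compound 2 to compound 3 (within the scatter). Compound 3 is expected to give about 12% in this assay, within a range from 2% to 25%.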

Compound 3, a percentage reported as inhibition, at one concentration (the size of the read-out at that concentration, not a potency): 27.1%
Estimate against measurement, compound 3: 15.1 percentage points below, and the stated range ends below it.
By their numbers in this assay, from the lowest: compound 1; then compound 2; then compound 3.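

Placing furan-2-yl in place of thiophen-2-yl on the aromatic carbon next to the ring nitrogen gives a number 12 percentage points higher from compound 2 to compound 3 (beyond the scatter) in this assay, the first single-change step in the series. This position therefore responds to an exchange of one ring hetero atom, oxygen for sulfur, although both groups have the same counts of heavy atoms, hydrogen-bond donors and hydrogen-bond acceptors. No measurement at hand accounts for this step.

The compounds shown leave open how this position would respond to a group outside the five-membered aromatic rings, such as an amine, a carboxylic acid or a longer alkyl chain. They also leave open whether the same exchange gives a similar step when the 3-hydroxyphenyl or 4-chlorophenyl group is replaced.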